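Methoxy Added to a Trimethoxyphenyl Chalcone Pyrazole

The source may hold more compounds than are shown below. What is called first, only, known or untested is meant among the compounds shown, and "the series" means these compounds.

Three pyrazole chalcones were tested in a functional assay on U-251 cells (Homo sapiens) for cytotoxicity, read by sulforhodamine B assay, with a stated time of 48 h, tested at 100 uM; on this read-out higher numbers stand for a weaker effect at the one concentration tested and lower numbers for a stronger effect. Compound 1 `COc1ccc(-c2cc(/C=C/C(=O)c3ccc(N)cc3)[nH]n2)cc1` gives -100%. Compound 3 `COc1ccc(-c2cc(/C=C/C(=O)c3ccc(N)cc3)[nH]n2)cc1OC` gives -96%, and the step of a number 4 percentage points higher from compound 1 to compound 3 (within the scatter) goes with the change (methoxy in place of hydrogen on an aromatic carbon). Compound 2 `COc1ccc(C(=O)/C=C/c2cc(-c3cc(OC)c(OC)c(OC)c3)n[nH]2)cc1OC` gives -99%; the difference between the core of compound 2 and the core of compound 1 is not broken down here, and its value sits within the scatter of both compound 1 and compound 3.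

Compound 4 `COc1cc(C(=O)/C=C/c2cc(-c3cc(OC)c(OC)c(OC)c3)n[nH]2)cc(OC)c1OC` has not been measured in this assay. It differs from compound 2 by methoxy in place of hydrogen on an aromatic carbon. Among the measured compounds shown here, this is the same kind of change as the one from compound 1 to compound 3, though the place differs: in compound 4 the entering methoxy is ortho to a methoxy group, meta to a large group and also meta to a methoxy group, whereas in compound 3 it is ortho to a methoxy group and meta to a large group only. The step is expected to be a number 1 percentage points higher from compound 2 to compound 4 (within the scatter), beside the earlier one, because a number 4 percentage points higher from compound 1 to compound 3 (within the scatter) stayed within the scatter. Compound 4 is thus estimated at -98%, between -105% and -85%.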

Compound 4, a percentage reported as activity, at one concentration (the size of the read-out at that concentration, not a potency): -99%
Estimate against measurement, compound 4: 1 percentage points above, within the range that was stated.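

In this assay, methoxy in place of hydrogen on an aromatic carbon gives no change at the digits printed from compound 2 to compound 4 (within the scatter). Set beside the step seen on the other core, this result shows no difference beyond what repeated measurement allows: the same change on two cores in this assay, a number 4 percentage points higher (within the scatter) from compound 1 to compound 3 and no change at the digits printed (within the scatter) from compound 2 to compound 4, 4 percentage points apart, within the scatter of two such steps. Within these compounds, then, the change carries from one core to the other without a step beyond the scatter, but this rests on only two pairs, read at a single concentration, and so shows neither that the change leaves potency untouched nor that it would behave the same way on a further core.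

The compounds shown leave open whether a group other than methoxy in the same place, such as a hydroxyl, a fluorine or a carboxylic acid, would also leave the read-out within the scatter. They also leave open how the methoxy step would read at any concentration other than the one tested.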